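Bromo to hydrogen on the fused ring: growth inhibition notes

The source may report more compounds than this note shows. Statements on the series, on what has been measured and on what is new or still open speak of the compounds shown alone.

Measured so far in an ADME assay on 184B5 cells (Homo sapiens) for cytotoxicity, read by sulforhodamine B assay, with a stated time of 48 h; on this read-out lower numbers stand for stronger inhibition of growth and higher numbers for weaker inhibition of growth:
compound 1 `O=C1C(=O)N(CN(c2ccccc2)c2ccccc2)c2ccccc21` gives 33700 nM
compound 2 `Cc1ccc2nc(/N=C3\C(=O)N(CN(C)C)c4cccc(Br)c43)sc2c1` gives 74800 nM
compound 3 `O=C1C(=O)N(CN(c2ccccc2)c2ccccc2)c2cccc(Br)c21` gives 98500 nM

Compounds 1 and 3 share one core, and the change between them is hydrogen in place of bromo on an aromatic carbon. The step it made in this assay is a 2.9-fold lower number from compound 3 to compound 1 (0.47 log units; beyond the scatter), so removing the bromo went with a lower number here.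

Compound 2 carries a different core; the difference between the two cores is not broken down here. Among the three numbers compound 2 stands second highest, near compound 3 and further from compound 1.

Compound 4 `Cc1ccc2nc(/N=C3\C(=O)N(CN(C)C)c4ccccc43)sc2c1` is not yet measured. For the measured compounds named here, it differs from compound 2 by hydrogen in place of bromo on an aromatic carbon, the same change as the one from compound 3 to compound 1, at a place described in the same words. Going by the values given here, only one example of this change is measured, on a different core, so the expectation rests on a single step. Among the compounds with values here, the step expected from compound 2 to compound 4 in this assay is a 2.9-fold lower number from compound 2 to compound 4 (0.46 log units; beyond the scatter), taken to be about as large as the measured one because a 2.9-fold lower number from compound 3 to compound 1 (0.47 log units; beyond the scatter) is the only guide available. On that basis compound 4 is estimated at 26000 nM, with a range from 10000 nM to 60000 nM, the width allowing for the change of core.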

Compound 4, concentration for 50% growth inhibition: 15600 nM
For compound 4 the middle estimate is 1.7-fold (0.22 log units) above the measured one; low and high end bracket the measured number.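

In this assay, hydrogen in place of bromo on an aromatic carbon gives a 4.8-fold lower number from compound 2 to compound 4 (0.68 log units; beyond the scatter), so the second core shows the change in the same direction as the first. On these two cores the change carries over, with the two steps agreeing in direction and no difference in size that can be told from the scatter: the same change on two cores in this assay, a 2.9-fold lower number (0.47 log units; beyond the scatter) from compound 3 to compound 1 and a 4.8-fold lower number (0.68 log units; beyond the scatter) from compound 2 to compound 4, 1.6-fold (0.21 log units) apart, within the scatter of two such steps

For the compounds shown here, this rests on only two pairs, in one assay on one cell type and with one place of substitution, so it does not show that the step would hold on a further core, and it gives no reason for the step.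

On these data alone, only bromo and hydrogen appear at this place on the ring, so it remains open how chloro, methoxy or a carboxylic acid there would read in this assay, and whether the numbers would follow any order across such groups. Also open, as far as these compounds go, is whether the same step would appear on a core whose side chain carries a cyclic amine such as morpholine.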